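One added methoxy on compound 2: what to expect

This account rests on a few compounds, and the source may have more. Where it says the series, first, only, none or still open, it means among the compounds named here.

Three compounds measured in a functional assay on MCF7 cells (Homo sapiens) for inhibition, read by sulforhodamine B assay, with a stated time of 48 h (on this read-out lower numbers stand for stronger inhibition of growth and higher numbers for weaker inhibition of growth), are these:
Compound 1 `COc1ccc(/C=C/C2(C)C=CC(=O)O2)c(OC)c1` gives 43500 nM
Compound 2 `COc1ccc(/C=C/C2(C)C=CC(=O)O2)cc1OC` gives 78900 nM
Compound 3 `COc1ccc(/C=C/C2(C)C=CC(=O)O2)c(OC)c1OC` gives 110000 nM

Among these three numbers, compound 2 lies within the scatter of the values on either side of it. Compound 4 `COc1cc(OC)c(OC)cc1/C=C/C1(C)C=CC(=O)O1` is still unmeasured and differs from compound 2 at one place, by methoxy in place of hydrogen on an aromatic carbon and in words methoxy in place of hydrogen on an aromatic carbon.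

Two measured steps make this same kind of exchange. One shows a 2.5-fold higher number from compound 1 to compound 3 (0.40 log units; beyond the scatter) and is a modest step beyond the scatter, while the other shows a 1.4-fold higher number from compound 2 to compound 3 (0.14 log units; within the scatter) and stays within it. Both run toward a higher number, but neither produces the arrangement of methoxy groups found in compound 4. In this assay a small step toward a higher number, meaning weaker inhibition of growth, is therefore expected, and it may not clear the scatter. The expected change is a 1.3-fold higher number from compound 2 to compound 4 (0.12 log units; within the scatter) and remains only an estimate. For compound 4 the estimated value is 105000 nM with an expected range from 50000 nM to 220000 nM around it.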

Compound 4, concentration for total growth inhibition: 144000 nM
Compound 4: middle estimate off by 1.4-fold (0.14 log units), on the low side, and the stated range covers the measured number.
By their numbers in this assay, from the lowest: compounds 1, 2, 3 and 4 (each within the scatter of the next, the first and the last beyond it).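

On compound 2, methoxy in place of hydrogen on an aromatic carbon, at the place ortho to a group of 9 heavy atoms, meta to one methoxy group and para to another, gives a 1.8-fold higher number from compound 2 to compound 4 (0.26 log units; within the scatter) in this assay, so this exchange at this new place does not clear the scatter. Reached from compound 1, the same kind of exchange gives a 3.3-fold higher number from compound 1 to compound 4 (0.52 log units; beyond the scatter), a modest step that, like the one from compound 1 to compound 3, is beyond the scatter. Of the four exchanges now measured, only the two starting from compound 1 clear the scatter, yet the gap between steps on the two cores stays within the scatter of two such steps, so no dependence on the core is shown: the same change on two cores in this assay, a 2.5-fold higher number (0.40 log units; beyond the scatter) from compound 1 to compound 3 and a 1.8-fold higher number (0.26 log units; within the scatter) from compound 2 to compound 4, 1.4-fold (0.14 log units) apart, within the scatter of two such steps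

Every ring shown carries only methoxy groups and hydrogen, which leaves open whether a hydroxy group, a fluorine atom or an amine at this place would give a step like that of methoxy. Also open, as far as these compounds go, is how a ring with a single methoxy group, or with none, would compare with these compounds.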